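Moving the hydroxamic acid around the phenyl ring

The source may report more compounds than this note shows. Statements on the series, on what has been measured and on what is new or still open speak of the compounds shown alone.

Compound 1 `O=C(NO)c1ccc(-c2cn([C@H]3C[C@H](C(=O)O)N(CCCc4ccccc4)C3)nn2)cc1`: in an assay on Sf9 cells for inhibition of histone deacetylase 11 (Homo sapiens), read by fluorescence, tested at 0.5 uM (on this read-out lower numbers stand for less inhibition and higher numbers for more inhibition at the one concentration tested (going by the name of the read-out)), compound 1 gives the limit < 10%.
Compound 2 `O=C(NO)c1cccc(-c2cn([C@H]3C[C@H](CO)N(CCCc4ccccc4)C3)nn2)c1`: in this assay compound 2 gives the limit < 10%.
Compound 3 `O=C(NO)c1cccc(-c2cn([C@H]3C[C@@H](CO)N(CCCc4ccccc4)C3)nn2)c1`: in this assay compound 3 gives the limit < 10%.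

Compound 2 stands at a limit of this assay, and every value shown sits at that same limit (the limit of < 10% in this assay, at which 3 of the 3 values shown sit), so none of the three compounds is separated from another. Going by the values given here, the one step between measured compounds, a step that the two limits leave unreadable from compound 2 to compound 3, cannot be sized, as both ends are limits; the pair differs only in configuration (the fact that compounds 2 and 3 differ only in the configuration as drawn). Compound 4 `O=C(NO)c1ccc(-c2cn([C@H]3C[C@H](CO)N(CCCc4ccccc4)C3)nn2)cc1` is compound 2 with 4-(hydroxycarbamoyl)phenyl in place of 3-(hydroxycarbamoyl)phenyl on an aromatic carbon. Among the compounds with values here, no measured step follows this change, so the expectation rests on where compound 2 stands and on compound 1, which also sits at its limit. Compound 4 is therefore expected to remain near the limit, with an estimated step that the limit leaves unreadable from compound 2 to compound 4 that should not exceed the scatter. The estimate for compound 4 is 5%, expected to fall between 0% and 15%.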

Compound 4, a percentage reported as inhibition, at one concentration (the size of the read-out at that concentration, not a potency): 18%
Beside the measured number, compound 4's estimate is 13 percentage points below it; measured number outside the range, above it.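

Going by these compounds alone, compound 4 is the first compound here to give a number: in this assay, compound 4 gives 18%. The other values remain at a limit: the limit of < 10% in this assay, at which 3 of the 4 values shown sit. This places a measurable reading on 4-(hydroxycarbamoyl)phenyl together with hydroxymethyl, with the aryl change giving a number at least 8 percentage points higher from compound 2 to compound 4 (that floor lies within the scatter), and the swap of carboxy for hydroxymethyl giving a number at least 8 percentage points higher from compound 1 to compound 4 (that floor lies within the scatter). Since both are floors within the scatter, neither change can yet be called a real gain, although neither is ruled out.

On these data alone, it remains open whether 4-(hydroxycarbamoyl)phenyl would give a reading with the other configuration drawn in compound 3. As far as these compounds go, it is also open how an amine would compare in place of hydroxymethyl on the saturated ring carbon.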